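This account rests on a few compounds, and the source may have more. Where it says the series, first, only, none or still open, it means among the compounds named here.

Of the compounds shown here, three have been tested in a physicochemical assay for solubility, in phosphate buffer, measured as kinetic solubility, at pH 7.4 (on this read-out higher numbers stand for higher solubility and lower numbers for lower solubility), and none of them yields a number. Compound 1 `Cc1oc(-c2ccc(Cl)cc2)nc1CN1CCC(C(=O)NCCCN2C[C@H](C)C[C@H](C)C2)CC1` gives > 72 ug/mL, which is a limit of the assay. Compound 2 `Cc1ccccc1-c1nc(CN2CCC(C(=O)NCCCN3CCCCC3)CC2)c(C)o1` gives > 65 ug/mL, again a limit. Compound 3 `Cc1oc(-c2c(F)cccc2F)nc1CN1CCC(C(=O)NCCCN2C[C@H](C)C[C@H](C)C2)CC1` gives > 72 ug/mL, also a limit. Compound 3 thus stands at the limit of > 72 ug/mL in this assay, at which 2 of the 3 values shown sit.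

The unmeasured compound 4 `Cc1oc(-c2c(Cl)cccc2C(F)(F)F)nc1CN1CCC(C(=O)NCCCN2C[C@H](C)C[C@H](C)C2)CC1` keeps the rest of compound 3 and carries 2-chloro-6-(trifluoromethyl)phenyl in place of 2,6-difluorophenyl on an aromatic carbon. For the measured compounds named here, the one measured change at this place is a step that the two limits leave unreadable from compound 1 to compound 3, and its size cannot be read. Going by the values given here, both of its ends are limits, so no measured step gives a size to carry over to the change at hand. The expectation therefore rests on compound 3, whose > 72 ug/mL is a limit, and no step beyond the usual scatter is expected in this assay. The expected change is an at least 1.0-fold lower number from compound 3 to compound 4 (0.01 log units; that floor lies within the scatter). Compound 4 is estimated at 70 ug/mL, with an expected range from 35 ug/mL to 85 ug/mL, and a limit rather than a number is expected to be the more likely report.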

Compound 4, solubility: 65.1 ug/mL
Beside the measured number, compound 4's estimate is 1.1-fold (0.03 log units) above it, within the range that was stated.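

In this assay compound 4 gives 65.1 ug/mL, the first number rather than a limit among the compounds shown, and it carries the larger aryl group, with 11 heavy atoms entering where 8 leave. Its exchange for 2,6-difluorophenyl is an at least 1.1-fold lower number from compound 3 to compound 4 (0.04 log units; that floor lies within the scatter), and its exchange for 4-chlorophenyl is an at least 1.1-fold lower number from compound 1 to compound 4 (0.04 log units; that floor lies within the scatter), so what this carbon of the five-membered ring now offers is a floor on each step, and neither floor by itself passes the scatter. These steps remain floors, and the step between the two earlier aryl groups remains unreadable, because the values of compound 1 and compound 3 are limits: the limit of > 72 ug/mL in this assay, at which 2 of the 4 values shown sit.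

Going by these compounds, how far compound 1 and compound 3 really lie from compound 4 stays open, and with it whether the 2-chloro-6-(trifluoromethyl)phenyl group changes the reading by a real margin or hardly at all. Also open is what a pyridine ring or a phenyl ring bearing a carboxylic acid would give at this place on the shared core, since every aryl group shown carries only halogen, trifluoromethyl or methyl substituents.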